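The compounds below may be only part of what the source reports. "The series", "measured", "known", "first", "only" and "open" are said of these compounds alone.

Of the compounds shown here, two carry the measured numbers so far. In an assay for inhibition of histone deacetylase 8 (Homo sapiens), read by fluorescence, with a stated time of 15 min (a higher number here means a weaker inhibitor, a lower number a stronger inhibitor), compound 1 `C[C@@H](N)C(=O)NCc1nnc(-c2ccccc2)o1` gives 98 nM, and compound 2 `COc1ccc(-c2nnc(CNC(=O)CN)o2)cc1` gives 142 nM. Compound 2 holds the highest of the two numbers, with compound 1 nearest, and the gap between the two values lies within the scatter, so no order can be read from them.

The unmeasured compound 3 `COc1ccc(-c2nnc(CNC(=O)[C@@H](C)N)o2)cc1` differs from compound 2 by one change: methyl in place of hydrogen on a saturated chain carbon bound to an amine nitrogen and a carbonyl carbon. Among the compounds with values here, no step between two measured compounds shows this change on its own. In this assay, the step of a 1.4-fold lower number from compound 2 to compound 3 (0.15 log units; within the scatter) is expected to be small, if anything toward a lower number, and to stay within the scatter. Compound 3 is estimated to give 100 nM, with a range from 40 nM to 250 nM, because compound 1, which already carries the 1-aminoethyl group, gives 98 nM.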

Compound 3, half-maximal inhibitory concentration: 153 nM
For compound 3 the middle estimate is 1.5-fold (0.18 log units) below the measured one; the measured number falls inside the stated range.
By their numbers in this assay, from the lowest: compounds 1, 2 and 3 (each within the scatter of the next).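

The change from aminomethyl to 1-aminoethyl, methyl in place of hydrogen on a saturated chain carbon bound to an amine nitrogen and a carbonyl carbon, can now be read on its own in this assay as a 1.1-fold higher number from compound 2 to compound 3 (0.03 log units; within the scatter) and so cannot be told apart from repeat measurement. Within the data shown here, the same compound gives the first reading of methoxy in place of hydrogen on an aromatic carbon, with the 1-aminoethyl group present in both compounds, as a 1.6-fold higher number from compound 1 to compound 3 (0.19 log units; within the scatter) and this step also cannot be told apart from repeat measurement. No supporting data are available to explain either step.

The compounds shown leave open how an ethyl or benzyl group would read on that chain carbon, and how the opposite configuration of the 1-aminoethyl group would read. They also leave open how a chlorine or a hydroxyl would read in place of the methoxy group.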